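Trading Methoxy for Allyl on the Aromatic Carbon

This account rests on a few compounds, and the source may have more. Where it says the series, first, only, none or still open, it means among the compounds named here.

Compound 3 `COc1ccc(C(=O)CCCN2CCC(C(O)(c3ccccc3)c3ccccc3)CC2)cc1` gives the highest number of the three measured compounds in an in vitro assay on Sf9 cells for inhibition of cytochrome P450 2J2 (Homo sapiens) (on this read-out higher numbers stand for weaker inhibition and lower numbers for stronger inhibition), at 7600 nM. Compound 1 `CCc1ccc(C(=O)CCCN2CCC(C(O)(c3ccccc3)c3ccccc3)CC2)cc1` gives 600 nM in this assay, and compound 2 `O=C(CCCN1CCC(C(O)(c2ccccc2)c2ccccc2)CC1)c1ccc(CCO)cc1` gives 1300 nM. Compound 4 `C=CCc1ccc(C(=O)CCCN2CCC(C(O)(c3ccccc3)c3ccccc3)CC2)cc1` differs from compound 3 in one place: allyl in place of methoxy on an aromatic carbon. The step that bears most on this is a 13-fold higher number from compound 1 to compound 3 (1.10 log units; beyond the scatter), where ethyl in place of methoxy went with the stronger inhibition, and allyl is the nearer relative of ethyl here; a 5.8-fold higher number from compound 2 to compound 3 (0.77 log units; beyond the scatter) points the same way. A large step downward is therefore expected, an 11-fold lower number from compound 3 to compound 4 (1.04 log units; beyond the scatter). Compound 4 is estimated at 700 nM, with a range from 300 nM to 2000 nM.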

Compound 4, half-maximal inhibitory concentration: 400 nM
Beside the measured number, compound 4's estimate is 1.8-fold (0.24 log units) above it; measured number inside the range.
By their numbers in this assay, from the lowest: compounds 4 and 1 (each within the scatter of the next); then compound 2; then compound 3.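

Allyl and ethyl cannot be told apart at this position: a 1.5-fold lower number from compound 1 to compound 4 (0.18 log units; within the scatter) leaves the added double bond with no readable effect on the number. Allyl also gives a 19-fold lower number from compound 3 to compound 4 (1.28 log units; beyond the scatter) against methoxy and a 3.3-fold lower number from compound 2 to compound 4 (0.51 log units; beyond the scatter) against 2-hydroxyethyl, so among these four compounds the two groups made only of carbon and hydrogen give the lowest numbers. Nothing shown here accounts for these steps.

The compounds shown leave open how an amine or a carboxylic acid would fare at this position. They also leave open whether a longer chain such as butyl would hold the number at this level.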